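Working notes on the quinazolinone-free core series: aryl substituent removal

The compounds below may be only part of what the source reports. "The series", "measured", "known", "first", "only" and "open" are said of these compounds alone.

Measured compounds:
compound 1 `CCCC1Nc2ccc(C(C)C)cc2C(=O)N1Cc1ccc(-c2ccccc2-c2nn[nH]n2)cc1`: 50 nM
compound 2 `CCCCC1Nc2ccc(C(C)C)cc2C(=O)N1Cc1ccc(-c2ccccc2-c2nn[nH]n2)cc1`: 1100 nM
compound 3 `CCC1Nc2ccc(C)cc2C(=O)N1Cc1ccc(-c2ccccc2-c2nn[nH]n2)cc1`: 13000 nM

In an assay on adrenal cortex for inhibition of angiotensinogen (Rattus norvegicus) (on this read-out higher numbers stand for weaker inhibition and lower numbers for stronger inhibition), compound 1 gives the lowest number of the three shown. The nearest neighbour is compound 2, reached by a single change: a 22-fold higher number from compound 1 to compound 2 (1.34 log units; beyond the scatter). Compound 3 lies further away still, and it differs from compound 1 in two places, the chain and the aryl substituent, so its value cannot be assigned to either change alone.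

Compound 4 `CCCC1Nc2ccccc2C(=O)N1Cc1ccc(-c2ccccc2-c2nn[nH]n2)cc1` differs from compound 1 by hydrogen in place of isopropyl on an aromatic carbon. Among the measured compounds shown here, no measured step isolates this change: the only single step, from compound 1 to compound 2, concerns the chain. Compound 3, with a smaller aryl group and a shorter chain, gives the weakest number seen, which hints that a smaller aryl substituent may cost potency, but the chain change is confounded with it. The expectation is therefore a weakening step of moderate size, an 8.0-fold higher number from compound 1 to compound 4 (0.90 log units; beyond the scatter), with wide uncertainty. Compound 4 is estimated at 400 nM, in the range 100 nM to 2500 nM.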

Compound 4, half-maximal inhibitory concentration: 540 nM
Compound 4: the middle estimate sits 1.4-fold (0.13 log units) below what was measured; the range from low to high includes it.
By their numbers in this assay, from the lowest: compound 1; then compound 4; then compound 2; then compound 3.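

In this assay the isopropyl on this aromatic carbon now has a step of its own, with the chain held constant: hydrogen in its place gives a large weakening beyond the scatter (an 11-fold higher number from compound 1 to compound 4 (1.03 log units; beyond the scatter)). Compound 3 could not show this, as it differs from compound 1 in both the chain and the aryl substituent, whereas this step shows that the aryl change alone is enough to weaken the number substantially. No available evidence accounts for the size of this step.

On these data alone, on the same chain, only isopropyl and hydrogen are compared at this carbon, so it remains open whether an ethyl, a methoxy or a chlorine there would stay close to compound 1 or to compound 4. Also open, as far as these compounds go, is whether removing the isopropyl would have a similar effect on the longer chain of compound 2.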